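The source may hold more compounds than are shown below. What is called first, only, known or untested is meant among the compounds shown, and "the series" means these compounds.

Measured so far:
compound 1, `CCOc1cc(C(C)(C)C)ccc1C1=NC(c2ccc(Cl)cc2)C(c2ccc(Cl)cc2)N1C(=O)NCCCCCCCC(=O)Nc1ccccc1N`, which in an assay on isolated protein for inhibition of E3 ubiquitin-protein ligase Mdm2 (Homo sapiens), read by fluorescence polarization, with a stated time of 30 min (a higher number here means a weaker inhibitor, a lower number a stronger inhibitor), gives 1020 nM
compound 2, `CCOc1cc(C(C)(C)C)ccc1C1=NC(c2ccc(Cl)cc2)C(c2ccc(Cl)cc2)N1C(=O)NCCCCCCCC(=O)NO`, which in this assay gives 340 nM

Of these two numbers, compound 2 has the lower one; the two are separated by the step of a 3.0-fold lower number from compound 1 to compound 2 (0.48 log units; beyond the scatter). Compound 3, `CCOc1cc(C(C)(C)C)ccc1C1=NC(c2ccc(Cl)cc2)C(c2ccc(Cl)cc2)N1C(=O)NCCCCCCC(=O)Nc1ccccc1N`, differs from compound 2 by (2-aminophenyl)carbamoyl in place of (hydroxycarbamoyl)methyl on a saturated chain carbon, six bonds along the chain from an amide-type nitrogen. Within the data shown here, only that one measured step bears on this change: it swapped the same two end groups in the opposite direction, and the shortening of the chain has no measured counterpart. The expected step is therefore its reverse, modest and toward a higher number: a 2.6-fold higher number from compound 2 to compound 3 (0.42 log units; beyond the scatter). Compound 3 is thus estimated at 900 nM, within 300 nM to 2700 nM.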

Compound 3, inhibition constant: 620 nM
Estimate against measurement, compound 3: 1.5-fold (0.16 log units) above; the measured number falls inside the stated range.
By their numbers in this assay, from the lowest: compounds 2, 3 and 1 (each within the scatter of the next, the first and the last beyond it).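

In this assay, replacing ((2-aminophenyl)carbamoyl)methyl with (2-aminophenyl)carbamoyl at this saturated chain carbon gives a 1.6-fold lower number from compound 1 to compound 3 (0.22 log units; within the scatter) and so stays within the scatter. The change between the two end groups, read here with the chain length changing too, gives a 1.8-fold higher number from compound 2 to compound 3 (0.26 log units; within the scatter) and also stays within the scatter, so these compounds cannot be told apart at this position. Nothing available explains this result.

On these data alone, it remains open how a carboxylic acid or a primary amine would read at this chain end. A longer chain, or (hydroxycarbamoyl) directly on this carbon, is equally unresolved.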